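Expected cytotoxicity of compound 4 against Vero cells

The compounds below may be only part of what the source reports. "The series", "measured", "known", "first", "only" and "open" are said of these compounds alone.

Compound 1 `O=C(O)c1ccccc1C1CC(c2cc3ccccc3o2)=NN1C(=O)c1ccncc1`: in an ADME assay on Vero cells (Chlorocebus sabaeus) for cytotoxicity, read by MTT assay, with a stated time of 72 h (on this read-out lower numbers stand for stronger inhibition and higher numbers for weaker inhibition), compound 1 gives > 170000 nM, which is a limit of the assay and not a number.
Compound 2 `O=C(c1ccncc1)N1N=C(c2cc3ccccc3o2)CC1/C=C/c1ccccc1`: in this assay compound 2 gives > 212000 nM, again only a limit.
Compound 3 `CCn1cc(C(=O)N2N=C(c3cc4ccccc4o3)CC2c2ccc(N(C)C)cc2)c(=O)c2ccc(C)nc21`: in this assay compound 3 gives > 206000 nM, also a limit.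

Compound 3 therefore stands where the other two stand: none of the three gave a readable number in this assay, each sitting at a limit (the limit of > 170000 nM in this assay, at which 1 of the 3 values shown sits, (the limit of > 206000 nM in this assay, at which 1 of the 3 values shown sits), (the limit of > 212000 nM in this assay, at which 1 of the 3 values shown sits)). Among the compounds with values here, the one step between measured compounds that differ in a single place, a step that the two limits leave unreadable from compound 1 to compound 2, is unreadable for the same reason.

Compound 4 `CCn1cc(C(=O)N2N=C(c3cc4ccccc4o3)CC2c2ccccc2Cl)c(=O)c2ccc(C)nc21` differs from compound 3 by 2-chlorophenyl in place of 4-(dimethylamino)phenyl on a saturated ring carbon. No measured step bears on this change, and the only step shown has no readable size. Nothing in the numbers points toward a change beyond the scatter. The estimate for compound 4 in this assay is therefore 200000 nM, with a range from 100000 nM to 400000 nM, and it is expected to be reported once more as a limit. This estimate means an expected step of an at least 1.0-fold lower number from compound 3 to compound 4 (0.01 log units; that floor lies within the scatter), that is, none beyond the scatter.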

Compound 4, half-maximal inhibitory concentration: > 178000 nM
Compound 4 was reported as a limit (the forecaster's own chance of this, stated with the estimate: 85%); the middle value does not contradict the limit.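

In this assay, compound 3 and compound 4 are both reported only as limits and not as numbers, so the step between them, 2-chlorophenyl in place of 4-(dimethylamino)phenyl, cannot be read. The compounds shown leave open at what concentration, if any, these cells would be affected, and whether changing groups on the shared core matters.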